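The compounds below may be only part of what the source reports. "The series", "measured", "known", "first", "only" and "open" are said of these compounds alone.

Three compounds have been measured so far in a functional assay on SK-BR-3 cells (Homo sapiens) for inhibition, read by CCK-8 assay, with a stated time of 72 h, tested at 20 uM; a higher number here means more inhibition of growth at the concentration tested, a lower number less inhibition of growth:

Compound 1 `CCOC(=O)/C=C1/C(=O)Nc2ccccc21` gives 85.5%.
Compound 2 `CC(C)(C)OC(=O)/C=C1/C(=O)Nc2ccccc21` gives 87.3%.
Compound 3 `CN1C(=O)/C(=C/C(=O)OC(C)(C)C)c2ccccc21` gives 87.6%.

Compound 2 stands second highest of the three numbers, but all three lie close together. Its nearest neighbour is compound 3, reached by the step of a number 0.3 percentage points higher from compound 2 to compound 3 (within the scatter), and its furthest is compound 1, from which compound 2 is reached by the step of a number 1.8 percentage points higher from compound 1 to compound 2 (within the scatter). Both steps fall within the usual scatter, so the three compounds cannot be told apart on these numbers.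

Compound 4 `CCCCc1ccc2c(c1)/C(=C\C(=O)OC(C)(C)C)C(=O)N2` is the next compound, differing from compound 2 in one place: butyl in place of hydrogen on an aromatic carbon. Neither measured step bears directly on this change. The step from ethyl to tert-butyl at the ester and the step from hydrogen to methyl at the ring nitrogen both concern other parts of the shared core, and both stayed within the scatter. There is thus no measured change on the aromatic ring to lean on, and nothing suggests a step beyond the scatter in this assay.

Compound 4 is therefore expected to give about 85%, between 70% and 95%, an expected step of a number 2.3 percentage points lower from compound 2 to compound 4 (within the scatter).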

Compound 4, percent growth inhibition at one concentration: 87.8%
Compound 4: the middle estimate sits 2.8 percentage points below what was measured, and the stated range covers the measured number.
By their numbers in this assay, from the lowest: compounds 1, 2, 3 and 4 (each within the scatter of the next).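

In this assay, butyl in place of hydrogen on an aromatic carbon gives a number 0.5 percentage points higher from compound 2 to compound 4 (within the scatter), so compound 2 and compound 4 cannot be told apart on this read-out. The earlier steps shown here concerned only the ester and the ring nitrogen, whereas this one shows that the six-membered aromatic ring of the shared core can carry a butyl chain at this position with no step beyond the scatter. Going by these compounds alone, nothing measured here explains why the number stays within the scatter of compound 2, so the result records only that this change left no visible mark on growth inhibition at the concentration tested.

On these data alone, it remains open whether an amine, a carboxylic acid or a longer chain on this aromatic carbon would also stay within the scatter of compound 2, and whether butyl on another carbon of the same ring would do so. A reading at a single concentration also leaves open whether compound 2 and compound 4 would separate at lower concentrations, where a difference between them might become visible.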